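A few compounds are considered here, and "the series" means these few. Any claim that something is new, unique, unknown or untested is made for them only; others in the source may bear on it.

Compound 2 `CCC#CCOc1cccc2ccc(N)nc12` shares its core with compound 1 `CC#CCCOc1cccc2ccc(N)nc12`. In an assay on cells with melanin-concentrating hormone receptor 1 (Homo sapiens) as the target, read by radioligand binding (on this read-out lower numbers stand for stronger inhibition and higher numbers for weaker inhibition), compound 1 gives > 2000 nM, which is a limit of the assay rather than a number. In this assay compound 2 likewise gives > 2000 nM, also a limit. Both values sit at the limit of > 2000 nM in this assay, at which 2 of the 2 values shown sit, so the step that the two limits leave unreadable from compound 1 to compound 2 cannot be read, and on the numbers shown compound 2 stands only at a limit. Compound 3 `COC(C)(C)CCOc1cccc2ccc(N)nc12` differs from compound 2 by 2-methoxy-2-methylpropyl in place of but-1-yn-1-yl on a saturated chain carbon bound to an oxygen on an aromatic ring. Within the data shown here, the only measured step, a step that the two limits leave unreadable from compound 1 to compound 2, bears on this change merely in that both of its ends rest at the limit; its size is not readable, so no size or direction can be drawn from it for this assay. With both measured compounds at the limit, compound 3 is expected to give 4000 nM, within a range from 1000 nM to 20000 nM. The step that the limit leaves unreadable from compound 2 to compound 3 is accordingly estimated as none beyond the scatter.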

Compound 3, half-maximal inhibitory concentration: 132 nM
The estimate for compound 3 lay 30-fold (1.48 log units) above the measured number; the measured number lies below the stated range.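

Until now this side chain gave no readable number, but in this assay, 2-methoxy-2-methylpropyl in place of but-1-yn-1-yl on a saturated chain carbon bound to an oxygen on an aromatic ring gives an at least 15-fold lower number from compound 2 to compound 3 (1.18 log units; beyond the scatter). The comparison with the other triple-bond compound points the same way, with an at least 15-fold lower number from compound 1 to compound 3 (1.18 log units; beyond the scatter), so a change at this position can move the read-out clearly on the shared core. Compound 1 and compound 2 remain limits rather than numbers, so the true size of both steps stays open: the limit of > 2000 nM in this assay, at which 2 of the 3 values shown sit.

The change removes the triple bond and brings in an oxygen and more heavy atoms all at once, and the compounds shown do not separate these features. As far as these compounds go, whether a longer plain carbon chain, or an amine in place of the methoxy group, would give a similar number also remains open.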